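The source may hold more compounds than are shown below. What is called first, only, known or untested is meant among the compounds shown, and "the series" means these compounds.

Measured compounds: compound 1, `O=S(=O)(O)c1cc(O)c(/N=N/c2ccc(O)c3ccc(O)cc23)c2ccccc12`, and compound 2, `Cc1[nH]n(C(C)(C)C)c(=O)c1/N=N/c1c(O)cc(S(=O)(=O)O)c2ccccc12`, both tested in an assay on BaF3 cells with thrombopoietin receptor (Homo sapiens) as the target, read by a luciferase reporter; a higher number here means a larger maximal response, a lower number a smaller maximal response.

In this assay compound 1 gives < 5%, which is a limit of the assay and not a number. In this assay compound 2 gives < 5%, again a limit and not a number. Compound 2 therefore stands at the floor of what the assay reports, as the limit of < 5% in this assay, at which 2 of the 2 values shown sit, makes plain, and nothing separates it from compound 1 on these numbers.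

Compound 3, `Cc1[nH]n(-c2cc(S(=O)(=O)O)ccc2Cl)c(=O)c1/N=N/c1c(O)cc(S(=O)(=O)O)c2ccccc12`, differs from compound 2 in one place: 2-chloro-5-sulfophenyl in place of tert-butyl on an aromatic nitrogen. Among the measured compounds shown here, no measured pair shows what such a change does in this assay. Since compound 2 sits at the limit, the step is expected to be none beyond the scatter: the step from compound 2 to compound 3 is estimated as a number no lower from compound 2 to compound 3 (the limit leaves the size open). Compound 3 is expected to give about 5%, with a range from 0% to 20%.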

Compound 3, largest response reached (reported as efficacy), in percent of the reference or control that the assay uses: < 5%
Compound 3: no number, only a limit (the forecaster's own chance of this, stated with the estimate: 70%); the middle value sits exactly at the limit.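

In this assay compound 3 gives < 5% as a limit and not a number. The step between compound 2 and compound 3 therefore cannot be read: the limit of < 5% in this assay, at which 3 of the 3 values shown sit. The compounds shown leave open whether any group on the aromatic nitrogen gives a maximal response clear of this limit.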